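Swapping the 2H-indazol-2-yl group of compound 2 for quinoxalin-2-yl

A few compounds are considered here, and "the series" means these few. Any claim that something is new, unique, unknown or untested is made for them only; others in the source may bear on it.

Among the measured compounds shown here, in an in vitro ADME assay on microsomes from liver (Rattus norvegicus) for pharmacokinetics (a higher number here means faster removal of the compound, a lower number slower removal), compound 2 (`Cc1nc(C(F)(F)F)ccc1C(=O)Nc1ccc(Cl)c(-n2cc3ccccc3n2)c1`) gives 99.3 mL/min/kg, the higher of the two numbers measured so far. For the measured compounds named here, the only other measured compound, compound 1 (`Cc1nc(C(F)(F)F)ccc1C(=O)Nc1ccc(Cl)c(-c2nc3ccccc3[nH]2)c1`), gives 3 mL/min/kg. Compound 3 (`Cc1nc(C(F)(F)F)ccc1C(=O)Nc1ccc(Cl)c(-c2cnc3ccccc3n2)c1`) keeps the core of compound 2 and changes one group: quinoxalin-2-yl in place of 2H-indazol-2-yl on an aromatic carbon. The group sits on an aromatic carbon, ortho to a chloro group and meta to a large group.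

Going by the values given here, one measured step bears on this place, and only indirectly: a 33-fold higher number from compound 1 to compound 2 (1.52 log units; beyond the scatter). Among the compounds with values here, that step, well beyond the scatter, shows that the group here can move the number a long way, but quinoxalin-2-yl itself has no measured precedent. Compound 2, at 99.3 mL/min/kg, lies at the top of the numbers seen so far, so a further rise seems less likely than a fall, and nothing supports a drop as large as the distance to compound 1. A modest step toward a lower number is therefore expected, a 2.2-fold lower number from compound 2 to compound 3 (0.34 log units; beyond the scatter). For compound 3 the estimated clearance is 45 mL/min/kg, with an expected range of 15 mL/min/kg to 110 mL/min/kg.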

Compound 3, clearance: 10.7 mL/min/kg
For compound 3 the middle estimate is 4.2-fold (0.62 log units) above the measured one; the whole stated range lies above it.
By their numbers in this assay, from the lowest: compound 1; then compound 3; then compound 2.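

Within this assay, the step of a 9.3-fold lower number from compound 2 to compound 3 (0.97 log units; beyond the scatter) shows that the high clearance of compound 2 does not carry over to every two-ring group at this position, ortho to a chloro group and meta to a large group. Quinoxalin-2-yl does not quite match 1H-benzimidazol-2-yl, however, as the step of a 3.6-fold higher number from compound 1 to compound 3 (0.55 log units; beyond the scatter) lies beyond the scatter, so the group 2H-indazol-2-yl gives the highest number among these three compounds but the two lower groups still remain distinct from each other. The fall from 2H-indazol-2-yl to quinoxalin-2-yl comes with a change from a five-membered to a six-membered ring bearing the two hetero atoms, with hydrogen-bond donor and acceptor counts unchanged, and no measurement available here accounts for the change in clearance.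

Three compounds cannot separate the part played by ring size from that of the placing of the ring nitrogens or of the atom through which each group is attached. Going by these compounds, it also remains open whether a single-ring group such as pyridin-2-yl or phenyl, or a small group such as methyl or an amine, would give a number nearer compound 1 or compound 2.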